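This account rests on a few compounds, and the source may have more. Where it says the series, first, only, none or still open, it means among the compounds named here.

Three analogues sharing one core have been run in an ADME assay on PC-3 cells (Homo sapiens) for cytotoxicity, read by sulforhodamine B assay, with a stated time of 48 h, tested at 10 uM; on this read-out higher numbers stand for more inhibition at the one concentration tested (going by the name of the read-out) and lower numbers for less inhibition. Compound 1 `COc1nc2ccc(Br)cc2cc1C(c1ccccc1)n1cc(C2CC2)nn1` gives 22.6%. Compound 2 `CCCCCCCc1cn(C(c2ccccc2)c2cc3cc(Br)ccc3nc2OC)nn1` gives 4.42%, and the step of a number 18.2 percentage points lower from compound 1 to compound 2 (beyond the scatter) is the only one among the three that lies beyond the scatter. Compound 3 `COc1nc2ccc(Br)cc2cc1C(c1ccccc1)n1cc(CCCCCO)nn1` gives 12.9% and stands second highest of the three numbers, with compound 2 nearest (a number 8.5 percentage points higher from compound 2 to compound 3 (within the scatter)) and compound 1 furthest (a number 9.7 percentage points lower from compound 1 to compound 3 (within the scatter)), both within the scatter.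

Compound 4 `COc1nc2ccc(Br)cc2cc1C(c1ccccc1)n1cc(CCCO)nn1` is not yet measured in this assay. It differs from compound 3 by hydroxy in place of 2-hydroxyethyl on a saturated chain carbon, three bonds along the chain from an aromatic carbon. The measured steps that bear on this are the two that alter the chain on the same aromatic carbon: a number 8.5 percentage points higher from compound 2 to compound 3 (within the scatter) and a number 9.7 percentage points lower from compound 1 to compound 3 (within the scatter), each within the scatter. The data contain no shortening of a hydroxy-bearing chain, so the expectation rests on the small size of those neighbouring steps. A step of a number 2.1 percentage points higher from compound 3 to compound 4 (within the scatter) is therefore expected, meaning none beyond the scatter. For compound 4 the estimate is 15%, with a range from 5% to 28%.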

Compound 4, a percentage reported as inhibition, at one concentration (the size of the read-out at that concentration, not a potency): 14.7%
The estimate for compound 4 lay 0.3 percentage points above the measured number; measured number inside the range.
By their numbers in this assay, from the lowest: compounds 2, 3, 4 and 1 (each within the scatter of the next, the first and the last beyond it).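

In this assay, going from 5-hydroxypentyl to 3-hydroxypropyl gives a number 1.8 percentage points higher from compound 3 to compound 4 (within the scatter), so these two hydroxy chains cannot be told apart at this position. The shorter hydroxy chain does separate from heptyl, with a number 10.3 percentage points higher from compound 2 to compound 4 (beyond the scatter), a step beyond the scatter where the 5-hydroxypentyl step from heptyl stayed within it, while it remains within the scatter of cyclopropyl, with a number 7.9 percentage points lower from compound 1 to compound 4 (within the scatter). No supporting data on the cause of these steps are at hand.

Whether the hydroxy itself matters, or only the chain length, stays open, since no unsubstituted propyl chain appears among the compounds shown. As far as these compounds go, how an amine or a carboxylic acid in place of the hydroxy would read at this position also remains open.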